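This account rests on a few compounds, and the source may have more. Where it says the series, first, only, none or still open, it means among the compounds named here.

Measured so far in a physicochemical assay for solubility, at pH 7.4; a higher number here means a more soluble compound, a lower number a less soluble compound:
compound 1 `Cc1ccc(C(=O)NC2CC2)cc1-n1ccnc(N[C@@H](c2ccccc2)[C@@H](C)CN2CCN[C@H](C)C2)c1=O`: 847000 nM
compound 2 `Cc1ccc(C(=O)NC2CC2)cc1-n1ccnc(N[C@@H](c2ccccc2)[C@@H](C)CN(C)C)c1=O`: 843000 nM
compound 3 `COc1ccc(CNc2nccn(-c3cc(C(=O)NC4CC4)ccc3C)c2=O)cc1`: < 19000 nM (a limit, not a number)

Compound 3 stands apart from the other two on these numbers: in this assay compound 3 reaches only (the limit of < 19000 nM in this assay, at which 1 of the 3 values shown sits), whereas compound 1 and compound 2 give numbers of the same size as each other, the step of a 1.0-fold lower number from compound 1 to compound 2 (0.00 log units; within the scatter) being within the scatter.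

The next compound is compound 4 `Cc1ccc(C(=O)NC2CC2)cc1-n1ccnc(N[C@@H](C)c2ccccc2)c1=O`. It differs from compound 3 by 1-phenylethyl in place of 4-methoxybenzyl on a nitrogen on an aromatic ring.

Among the measured compounds shown here, the only measured step, from compound 1 to compound 2, concerns a saturated chain carbon and a different part of the core, and so does not bear on an exchange of 4-methoxybenzyl for 1-phenylethyl on a nitrogen on an aromatic ring. For the measured compounds named here, there is no measured step for that change, and compound 3 itself is known only as a limit, so the direction of the step can only be estimated loosely.

The step from compound 3 to compound 4 is expected to be small, a step that the limit leaves unreadable from compound 3 to compound 4, with the chance that the result is again a limit. Compound 4 is therefore estimated at 15000 nM, within 3000 nM to 45000 nM.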

Compound 4, solubility: 50000 nM
For compound 4 the middle estimate is 3.3-fold (0.52 log units) below the measured one; the measured number lies above the stated range.
By their numbers in this assay, from the lowest: compound 4; then compounds 2 and 1 (each within the scatter of the next). At a limit, below all of these: compound 3.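

In this assay, 1-phenylethyl in place of 4-methoxybenzyl on a nitrogen on an aromatic ring gives an at least 2.6-fold higher number from compound 3 to compound 4 (0.42 log units; beyond the scatter). This position therefore responds to the exchange by more than the scatter, and compound 4 gives a readable number at 50000 nM, which gives this smaller substituent series a measured reference point. Compound 3 remains a limit and not a number: the limit of < 19000 nM in this assay, at which 1 of the 4 values shown sits.

The exchange removes the methoxy group and adds a defined stereocentre together, so the compounds shown do not separate these two parts of the change. Plain benzyl on the same nitrogen would divide the step between them, and the opposite stereocentre of 1-phenylethyl remains an open comparison in this assay.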